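The compounds below may be only part of what the source reports. "The series", "measured", "known", "first", "only" and "open" are said of these compounds alone.

Measured so far:
compound 1 `Cc1ccc(C(=O)Nc2sc3c(c2C(N)=O)CCOC3)s1` — 778 nM
compound 2 `CC1(C)Cc2c(sc(NC(=O)c3cccnc3O)c2C(N)=O)C(C)(C)O1` — 190 nM

Among the measured compounds shown here, in an assay on cells for positive allosteric modulation of Cystic fibrosis transmembrane conductance regulator variant F508del (Homo sapiens), with stated times of 10 min and 7 s, in the presence of a further agent that is not named here (on this read-out lower numbers stand for an effect already at smaller amounts and higher numbers for an effect only at larger amounts of compound), compound 2 gives the lowest of the two numbers known; compound 1 gives 778 nM, a higher number beyond the usual scatter. Compound 3 `CC1(C)Cc2c(sc(NC(=O)Cc3ccn[nH]3)c2C(N)=O)C(C)(C)O1` is not yet measured. It differs from compound 2 by one change, ((1H-pyrazol-5-yl)methyl in place of 2-hydroxypyridin-3-yl on a carbonyl carbon), so the amide carries (1H-pyrazol-5-yl)methyl in place of 2-hydroxypyridin-3-yl on a carbonyl carbon. For the measured compounds named here, no comparable step between measured compounds exists to guide the size. The step of a 3.2-fold higher number from compound 2 to compound 3 (0.50 log units; beyond the scatter) is expected to go toward a higher number, beyond the scatter. Compound 3 is estimated at 600 nM, with a range from 200 nM to 2000 nM.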

Compound 3, half-maximal effective concentration: 136 nM
Compound 3: the middle estimate sits 4.4-fold (0.64 log units) above what was measured; measured number outside the range, below it.
By their numbers in this assay, from the lowest: compounds 3 and 2 (each within the scatter of the next); then compound 1.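

Replacing 2-hydroxypyridin-3-yl with (1H-pyrazol-5-yl)methyl on a carbonyl carbon gives a 1.4-fold lower number from compound 2 to compound 3 (0.15 log units; within the scatter) in this assay, so this position accepts both a six-membered and a five-membered aromatic ring without a change beyond the scatter. The oxygen of the leaving group is not required for a value of this size in this pair. Nothing available explains why the two groups read alike. The ring and the methylene link change together here, so their separate contributions cannot be read. Going by these compounds, how a carboxylic acid or an amine would fare on this carbonyl carbon remains open.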